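One Double Bond Changed Among Inactive Stereoisomers

A few compounds are considered here, and "the series" means these few. Any claim that something is new, unique, unknown or untested is made for them only; others in the source may bear on it.

Compound 1 `C=C(C)[C@@H]1CC[C@](C)(O)[C@H]1/C=C/C(C)=C/[C@@H]1C[C@@]23[C@H](OCCC[C@@H]2/C(=C(\C)C=O)CC[C@]3(C)O)O1` and compound 2 `C=C(C)[C@H]1CC[C@@](C)(O)[C@@H]1/C=C/C(C)=C/[C@@H]1C[C@@]23[C@H](OCCC[C@@H]2/C(=C(/C)C=O)CC[C@]3(C)O)O1` were both tested in a functional assay on BV-2 cells (Mus musculus) for inhibition, read by Griess assay, with a stated time of 24 h; on this read-out higher numbers stand for weaker inhibition and lower numbers for stronger inhibition. Compound 1 gives > 10000 nM, which is a limit of the assay. Compound 2 gives > 10000 nM, also a limit, so it stands without a number of its own. Among the compounds with values here, the only measured step, a step that the two limits leave unreadable from compound 1 to compound 2, therefore has no readable size, and the limit of > 10000 nM in this assay, at which 2 of the 2 values shown sit, holds for the whole set. That step is purely one of configuration and includes a change at a double bond. Compound 3 `C=C(C)[C@H]1CC[C@@](C)(O)[C@@H]1/C=C/C(C)=C/[C@@H]1C[C@@]23[C@H](OCCC[C@@H]2/C(=C(\C)C=O)CC[C@]3(C)O)O1` departs from compound 2 in one place: the two compounds have the same atoms and bonds and differ only in configuration as drawn: 1 of 11 stereo elements differ; a double bond is drawn Z in compound 2 and E in compound 3. No step beyond the scatter is expected in this assay, and no direction can be read, because compound 2 gives > 10000 nM, a limit. The estimated change is a number no higher from compound 2 to compound 3 (the limit leaves the size open). Compound 3 is expected to lie near 10000 nM, within an estimated range of 4000 nM to 20000 nM, and most likely to be reported only as a limit.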

Compound 3, half-maximal inhibitory concentration: > 10000 nM
Compound 3: only a limit was reported; the forecaster's own chance of this, stated with the estimate: 75%; the middle value lies on the limit itself.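

Compound 3 gives > 10000 nM in this assay, a limit of the assay, so its steps from compound 1 and from compound 2 cannot be read. The compounds shown leave open whether configuration at the ring carbons or the double bond affects inhibition at all, since all share one result: the limit of > 10000 nM in this assay, at which 3 of the 3 values shown sit.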